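The source may report more compounds than this note shows. Statements on the series, on what has been measured and on what is new or still open speak of the compounds shown alone.

Compound 1 `FC(F)(F)c1ccc(CSc2nc(Nc3ccccc3C(F)(F)F)c3ccccc3n2)cc1` is measured in a functional assay on HGC-27 cells (Homo sapiens) for cytotoxicity, read by MTT assay, with a stated time of 72 h (a higher number here means a weaker inhibitor, a lower number a stronger inhibitor), only as a limit, reported as > 50000 nM, so it sits at the limit of > 50000 nM in this assay, at which 1 of the 3 values shown sits, and no number is known for it. Two related compounds give numbers: compound 2 `FC(F)(F)c1ccc(CSc2nc(Nc3cccc(Cl)c3)c3ccccc3n2)cc1` gives 19900 nM in this assay, and compound 3 `FC(F)(F)c1ccc(CSc2nc(Nc3cccc(Br)c3)c3ccccc3n2)cc1` gives 18300 nM. The step of an at least 2.5-fold lower number from compound 1 to compound 2 (0.40 log units; beyond the scatter) and the step of an at least 2.7-fold lower number from compound 1 to compound 3 (0.43 log units; beyond the scatter) are both beyond the scatter, while a 1.1-fold lower number from compound 2 to compound 3 (0.04 log units; within the scatter). Compound 4 `FC(F)(F)c1ccc(CSc2nc(Nc3ccc(Cl)cc3)c3ccccc3n2)cc1` differs from compound 1 by 4-chlorophenyl in place of 2-(trifluoromethyl)phenyl on a nitrogen on an aromatic ring. Whether a 4-chlorophenyl group behaves like the 3-chlorophenyl group of compound 2 is not shown by any measured pair, but a step of similar direction is expected, namely an at least 2.2-fold lower number from compound 1 to compound 4 (0.35 log units; beyond the scatter). For compound 4 the estimated value in this assay is 22000 nM, with a range from 8000 nM to 50000 nM.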

Compound 4, half-maximal inhibitory concentration: 14100 nM
For compound 4 the middle estimate is 1.6-fold (0.19 log units) above the measured one, within the range that was stated.
By their numbers in this assay, from the lowest: compounds 4, 3 and 2 (each within the scatter of the next). At a limit, above all of these: compound 1.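

On the nitrogen on an aromatic ring, 4-chlorophenyl in this assay extends the earlier result to a third halogen-bearing phenyl group, with an at least 3.5-fold lower number from compound 1 to compound 4 (0.54 log units; beyond the scatter). Moving from 3-chlorophenyl to 4-chlorophenyl does not separate the compounds, with a 1.4-fold lower number from compound 2 to compound 4 (0.15 log units; within the scatter), and neither does the change from 3-bromophenyl, with a 1.3-fold lower number from compound 3 to compound 4 (0.11 log units; within the scatter). The value of compound 1 remains a limit and not a number: the limit of > 50000 nM in this assay, at which 1 of the 4 values shown sits.

Left open is whether a methoxy group or an amine on that phenyl ring, in place of the halogen, would give a number in the range of compound 2, compound 3 and compound 4.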